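Methylsulfanyl Change Across Two Cores: Working Notes

The source may report more compounds than this note shows. Statements on the series, on what has been measured and on what is new or still open speak of the compounds shown alone.

Measured so far:
compound 1 `Cc1nsc2c1ncn2[C@@H]1O[C@H](CO)[C@@H](O)[C@@H]1O` — > 100000 nM in a functional assay on HFF cells (Homo sapiens) for inhibition; a lower number here means a stronger inhibitor, a higher number a weaker inhibitor
compound 2 `CSc1nc2c(C)nsc2n1[C@@H]1O[C@H](CO)[C@@H](O)[C@@H]1O` — > 100000 nM
compound 3 `Cc1nsc2c1ncn2[C@@H]1O[C@H](CO)[C@@H](O)[C@H]1O` — 150000 nM

The value of compound 1 in this assay is a limit of the assay and not a number. The value of compound 2 is likewise a limit. Compound 3 alone gives a number in this assay, and it sits far from the potent end. Of the three values shown, two are limits and one is a number, so comparisons within the set are thin.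

Compound 2 differs from compound 1 by methylsulfanyl in place of hydrogen on an aromatic carbon. The step that the two limits leave unreadable from compound 1 to compound 2 cannot be read, because the limit of > 100000 nM in this assay, at which 2 of the 3 values shown sit, caps both ends. Compound 3 differs from compound 1 by the two compounds have the same atoms and bonds and differ only in configuration as drawn: 1 of 4 stereo elements differ; a stereocentre at a saturated ring carbon is drawn S in compound 1 and R in compound 3; the step that the limit leaves unreadable from compound 1 to compound 3 is likewise not readable, and the two cores differ only in what the fact that compounds 1 and 3 differ only in the configuration as drawn states.

Compound 4 `CSc1nc2c(C)nsc2n1[C@@H]1O[C@H](CO)[C@@H](O)[C@H]1O` is not yet measured. It differs from compound 3 by methylsulfanyl in place of hydrogen on an aromatic carbon. Among the compounds with values here, this is the same change as the one from compound 1 to compound 2: the place lines agree word for word. That earlier step carries no readable size, so the expectation for compound 4 rests on the value of compound 3 alone and on the change having shown no readable effect from compound 1 to compound 2.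

Compound 4 is expected to give 150000 nM in this assay, with a range from 50000 nM to 500000 nM. The step of no change at the digits printed from compound 3 to compound 4 (within the scatter) is expected to stay within the usual scatter, and a limit rather than a number is a likely outcome.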

Compound 4, half-maximal inhibitory concentration: > 100000 nM
Compound 4 ended at the assay's limit (the forecaster's own chance of this, stated with the estimate: 60%); the middle value lies beyond the limit too.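

In this assay compound 4 gives > 100000 nM, a limit of the assay and not a number. Neither the step from compound 3 to compound 4 nor the step from compound 2 to compound 4 can be read. The compounds shown leave open whether methylsulfanyl in place of hydrogen, or the configuration drawn at the saturated ring carbon, changes inhibition at all.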